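The compounds below may be only part of what the source reports. "The series", "measured", "known", "first", "only" and "open" are said of these compounds alone.

Series notes. Compound 1 `COc1ccc(-c2nn3cc(-c4cccc(N)c4)nc3s2)cc1OC` carries a hydrogen on a nitrogen on an aromatic ring; in a functional assay on FM3A cells (Mus musculus) for inhibition, read by cell counting, with a stated time of 2 days (on this read-out higher numbers stand for weaker inhibition and lower numbers for stronger inhibition), compound 1 gives 13000 nM. Compound 2 `C=C(Br)C(=O)Nc1cccc(-c2cn3nc(-c4ccc(OC)c(OC)c4)sc3n2)c1` gives 110 nM, the lowest of the three numbers shown, with compound 3 `COc1ccc(-c2csc3nc(-c4cccc(N)c4)cn23)cc1` giving 11000 nM. Going by the values given here, the only single-place step measured, a 120-fold lower number from compound 1 to compound 2 (2.07 log units; beyond the scatter), shows that the (1-bromoethenyl)carbonyl in place of hydrogen on a nitrogen on an aromatic ring is what moves the numbers. Compound 4 `C=C(Br)C(=O)Nc1cccc(-c2cn3nc(-c4ccc(Cl)cc4)sc3n2)c1` keeps that group and differs from compound 2 at the other aromatic ring: 4-chlorophenyl in place of 3,4-dimethoxyphenyl on an aromatic carbon. Among the compounds with values here, no measured pair isolates a change at this aromatic carbon; compounds 1 and 3 differ in more than one place, and their values lie close to each other. The step bearing on compound 4 is thus only indirect, and the aryl swap is expected to move the number little, not clearly beyond the scatter in either direction. For compound 4 the estimate is 150 nM, range 40 nM to 600 nM. This corresponds to an expected step of a 1.4-fold higher number from compound 2 to compound 4 (0.13 log units; within the scatter).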

Compound 4, half-maximal inhibitory concentration: 2000 nM
Compound 4: middle estimate off by 13-fold (1.12 log units), on the low side, outside the stated range (above it).
By their numbers in this assay, from the lowest: compound 2; then compound 4; then compounds 3 and 1 (each within the scatter of the next).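

This aromatic carbon, next to the ring sulfur, is not a silent position: in this assay, 4-chlorophenyl in place of 3,4-dimethoxyphenyl gives an 18-fold higher number from compound 2 to compound 4 (1.26 log units; beyond the scatter) with the (1-bromoethenyl)carbonyl group held in place. That group alone therefore does not set the number, and the aryl group is a second place in the series where a single change moves the read-out beyond the scatter. Nothing available explains the size of this step.

The two aryl groups differ in more than one feature, so the step cannot be assigned to the loss of the two methoxy groups or to the entry of the chlorine. Going by these compounds, whether a plain phenyl or a phenyl carrying a carboxylic acid would fall nearer compound 2 or compound 4 remains open.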